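The compounds below may be only part of what the source reports. "The series", "measured", "known", "first", "only" and "open" are said of these compounds alone.

Measured compounds:
- compound 1 `C=C1C[C@]23C[C@@]1(O)CC[C@H]2c1cc(Br)c(O)c(C)c1[C@@H]3Cn1cc(-c2ccc(OC)cc2)nn1` — in a functional assay on MCF7 cells (Homo sapiens) for cytotoxicity, read by MTT assay, with a stated time of 4 days (a lower number here means a stronger inhibitor, a higher number a weaker inhibitor), compound 1 gives > 20000 nM, a limit of the assay rather than a number.
- compound 2 `Cc1c(O)ccc2c1[C@H](Cn1cc(-c3ccc(C(F)(F)F)cc3)nn1)[C@@]13CC(=O)[C@@](C)(CC[C@@H]21)C3` — in this assay compound 2 gives > 20000 nM, again a limit rather than a number.

Going by the values given here, compound 1 thus stands only at a limit: the assay did not return a number for it, and the one other value shown, that of compound 2, is a limit as well. Both measured values sit at the limit of > 20000 nM in this assay, at which 2 of the 2 values shown sit, so nothing has yet been seen to inhibit in this range.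

Compound 3 `C=C1C[C@]23C[C@@]1(O)CC[C@H]2c1cc(Br)c(O)c(C)c1[C@@H]3Cn1cc(-c2ccc(C(F)(F)F)cc2)nn1` has not been measured. It arises from compound 1 by trifluoromethyl in place of methoxy on an aromatic carbon. Among the compounds with values here, no step between two measured compounds is available to size this change, so the expectation rests on the two limits alone. Compound 2 already carries the trifluoromethyl group on a different core and also sits at the limit. The step from compound 1 to compound 3 is therefore expected to be a step that the limit leaves unreadable from compound 1 to compound 3, meaning no change beyond the scatter. Compound 3 is estimated at 30000 nM, within 10000 nM to 100000 nM.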

Compound 3, half-maximal inhibitory concentration: 8100 nM
The estimate for compound 3 lay 3.7-fold (0.57 log units) above the measured number, outside the stated range (below it).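

In this assay compound 3 gives 8100 nM, the first actual number among the compounds shown, so the group at this place, on an aromatic carbon para to a large group, can shift the read-out on this core. Trifluoromethyl in place of methoxy brings an at least 2.4-fold lower number from compound 1 to compound 3 (0.39 log units; beyond the scatter). That step is a floor and not a measured size, because it starts from a limit of the assay rather than from a number: the limit of > 20000 nM in this assay, at which 2 of the 3 values shown sit.

The compounds shown leave open whether this shift is particular to trifluoromethyl or would also appear with other groups at the same place, such as a chlorine atom, a nitrile, an amine or a carboxylic acid. A single step at a single place also cannot show whether the same exchange would act in the same way on a different core, or how large the true difference between the methoxy and trifluoromethyl compounds is.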